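Swapping a Pyridine Carbonyl for a Propyl Carbonyl

The source may hold more compounds than are shown below. What is called first, only, known or untested is meant among the compounds shown, and "the series" means these compounds.

Compound 1 `CC(C)CC(=O)N1CCc2cc(CNC(=O)C3CC3)ccc21` gives 35% in an assay on HEK293 cells for inhibition of Indoleamine 2,3-dioxygenase 1 (Homo sapiens), tested at 10 uM; a higher number here means more inhibition at the concentration tested (going by the name of the read-out), a lower number less inhibition.
Compound 2 `CC(C)CC(=O)N1CCc2cc(CNC(=O)c3cccnc3)ccc21` gives 86% in this assay.
Compound 3 `CCC(=O)NCc1ccc2c(c1)CCN2C(=O)c1ccccc1` gives 41% in this assay.

Among these three numbers compound 2 stands highest in this assay; its nearest neighbour is compound 3, and compound 1 lies furthest away, both gaps being beyond the scatter. The next compound, compound 4 `CCCC(=O)NCc1ccc2c(c1)CCN2C(=O)CC(C)C`, keeps the core of compound 2 and changes one group: propyl in place of pyridin-3-yl on a carbonyl carbon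

Going by the values given here, one measured step bears directly on this position. Going the other way, from a small saturated group to the aromatic one, a number 51 percentage points higher from compound 1 to compound 2 (beyond the scatter). Compound 4 now takes the aromatic group away again and puts a short chain in its place. Compound 3, which also carries a short chain on this carbonyl carbon, sits close to compound 1 in this assay. On this basis a large drop is expected for compound 4, of about a number 48 percentage points lower from compound 2 to compound 4 (beyond the scatter). Compound 4 is therefore estimated at 38% in this assay, with a likely range from 15% to 60%.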

Compound 4, a percentage reported as inhibition, at one concentration (the size of the read-out at that concentration, not a potency): 64%
Estimate against measurement, compound 4: 26 percentage points below, outside the stated range (above it).
By their numbers in this assay, from the lowest: compounds 1 and 3 (each within the scatter of the next); then compound 4; then compound 2.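

At this position on the carbonyl carbon, the ring-free propyl group stands apart from both ring-bearing groups in this assay: the measurements give a number 22 percentage points lower from compound 2 to compound 4 (beyond the scatter) and also a number 29 percentage points higher from compound 1 to compound 4 (beyond the scatter) in the same assay. The three compounds that differ only in this place therefore rank in the order cyclopropyl, propyl, pyridin-3-yl, with every step beyond the scatter, so a group without a ring and without a hetero atom can still reach a number well above that of compound 1, though not that of compound 2. Nothing at hand accounts for this order.

Going by these compounds, whether a phenyl group on this carbonyl carbon would stay near compound 2, and whether a longer chain such as pentyl would rise above compound 4 or fall back towards compound 1, remains open. The order also rests on a single read-out at one concentration and on the shared core alone, so it is unclear whether it would hold for potency or with a different group on the other amide.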